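A Chlorine on the Pendant Phenyl of Compound 1

The source may report more compounds than this note shows. Statements on the series, on what has been measured and on what is new or still open speak of the compounds shown alone.

Compound 1 `O=C(NCc1cn(Cc2ccc(F)cc2)nn1)c1cn(-c2ccccc2)nc1-c1ccccc1` gives 1600 nM in a functional assay on HeLa cells (Homo sapiens) for antiproliferative activity, read by sulforhodamine B assay, with a stated time of 48 h; on this read-out higher numbers stand for weaker inhibition of growth and lower numbers for stronger inhibition of growth.
Compound 2 `COc1ccc(Cn2cc(CNC(=O)c3cn(-c4ccccc4)nc3-c3ccccc3)nn2)cc1` gives 6900 nM.
Compound 3 `COc1cc(Cn2cc(CNC(=O)c3cn(-c4ccccc4)nc3-c3ccccc3)nn2)cc(OC)c1` gives 12200 nM.

Compound 1 has the lowest number of the three, with a 4.3-fold higher number from compound 1 to compound 2 (0.63 log units; beyond the scatter) and a 7.6-fold higher number from compound 1 to compound 3 (0.88 log units; beyond the scatter) as the two moves away from it. Both of those steps alter the benzyl group on the far end of the molecule, while compound 4 `O=C(NCc1cn(Cc2ccc(F)cc2)nn1)c1cn(-c2ccccc2)nc1-c1ccc(Cl)cc1` is changed elsewhere: chloro in place of hydrogen on an aromatic carbon, on the phenyl carried by the shared core. Among the compounds with values here, no measured step touches that phenyl, so the three numbers give no direct guide for this change. With nothing to point either way, the step from compound 1 to compound 4 is expected to stay roughly within the scatter, a 1.2-fold lower number from compound 1 to compound 4 (0.09 log units; within the scatter). Compound 4 is therefore estimated at 1300 nM, between 400 nM and 4500 nM.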

Compound 4, concentration for 50% growth inhibition: 2800 nM
For compound 4 the middle estimate is 2.2-fold (0.33 log units) below the measured one, within the range that was stated.
By their numbers in this assay, from the lowest: compounds 1 and 4 (each within the scatter of the next); then compounds 2 and 3 (each within the scatter of the next).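

Chloro in place of hydrogen on the phenyl of the shared core, para to a large group, gives a 1.8-fold higher number from compound 1 to compound 4 (0.24 log units; within the scatter) in this assay. Within the data shown here, this is the first view of that phenyl, and unlike the two steps away from compound 1 on the far benzyl group, this one does not separate from the scatter. No supporting data bear on why this is so.

A single chloro cannot show how this phenyl responds to other groups. An amine or a carboxylic acid at the same place remains an open test.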